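A few compounds are considered here, and "the series" means these few. Any claim that something is new, unique, unknown or untested is made for them only; others in the source may bear on it.

Compound 1 `CCNc1nc(-c2ccccc2)nc2c1nnn2Cc1ccccc1Cl`: 463000000 nM in an assay on isolated protein for binding affinity to adenosine receptor A1 (Bos taurus); on this read-out higher numbers stand for weaker inhibition and lower numbers for stronger inhibition
Compound 2 `CCNc1nc(-c2ccccc2)nc2c1nnn2Cc1ccccc1F`: 11000000 nM in this assay

For the measured compounds named here, compound 2 stands lowest of the two numbers in this assay; its only neighbour is compound 1, with a 42-fold lower number from compound 1 to compound 2 (1.62 log units; beyond the scatter). Compound 3 `CCNc1nc(-c2ccccc2)nc2c1nnn2Cc1ccccc1` is not yet measured. It differs from compound 2 by hydrogen in place of fluoro on an aromatic carbon. Going by the values given here, the single step bearing on this change is the halogen swap from compound 1 to compound 2, which was large. Whether removing the halogen altogether continues in that direction is uncertain, so only a modest step is expected, a 2.2-fold lower number from compound 2 to compound 3 (0.34 log units; beyond the scatter). Compound 3 is therefore estimated at 5000000 nM, with a range from 1000000 nM to 30000000 nM.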

Compound 3, inhibition constant: 91000000 nM
Beside the measured number, compound 3's estimate is 18-fold (1.26 log units) below it; the whole stated range lies below it.
By their numbers in this assay, from the lowest: compound 2; then compound 3; then compound 1.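

In this assay, an 8.3-fold higher number from compound 2 to compound 3 (0.92 log units; beyond the scatter) stands against a 5.1-fold lower number from compound 1 to compound 3 (0.71 log units; beyond the scatter) for the same place on the ring, so hydrogen falls between the two halogens. At this place, fluoro gives the lowest number and chloro the highest, so the presence of a halogen alone does not set the direction of change. Nothing measured here accounts for this order.

Still open, on these data alone, is where a methyl, a methoxy or an amine at this place would fall relative to these three compounds. Also open, as far as these compounds go, is whether the same order would hold with bromo.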